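The source may hold more compounds than are shown below. What is called first, only, known or untested is meant among the compounds shown, and "the series" means these compounds.

Measured in a functional assay on MIA PaCa-2 cells (Homo sapiens) for inhibition, read by MTT assay, with a stated time of 72 h; on this read-out higher numbers stand for weaker inhibition of growth and lower numbers for stronger inhibition of growth:
Compound 1 `COc1ccc(CNCCCNS(=O)(=O)c2cc(C(F)(F)F)cc(C(F)(F)F)c2)cc1OC` gives 2800 nM.
Compound 2 `O=S(=O)(NCCCNCC1COc2ccccc2O1)c1cc(C(F)(F)F)cc(C(F)(F)F)c1` gives 2600 nM.
Compound 3 `O=S(=O)(NCCCNCc1ccccc1)c1cc(C(F)(F)F)cc(C(F)(F)F)c1` gives 11000 nM.

Compound 3 has the highest number of the three, and its steps to both compound 1 and compound 2 lie beyond the scatter. Compound 4 `COc1cccc(CNCCCNS(=O)(=O)c2cc(C(F)(F)F)cc(C(F)(F)F)c2)c1` differs from compound 3 by methoxy in place of hydrogen on an aromatic carbon. Going by the values given here, the steps that bear on this are a 3.9-fold higher number from compound 1 to compound 3 (0.59 log units; beyond the scatter) and a 4.2-fold higher number from compound 2 to compound 3 (0.63 log units; beyond the scatter); both remove oxygen substitution on the benzyl ring and both raise the number by a modest amount. Compound 4 restores a single methoxy, so a modest step downward in this assay is expected, smaller than those two steps, estimated as a 2.0-fold lower number from compound 3 to compound 4 (0.30 log units; within the scatter). For compound 4 the estimate is 5500 nM, with a range from 2500 nM to 12000 nM.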

Compound 4, concentration for 50% growth inhibition: 3400 nM
For compound 4 the middle estimate is 1.6-fold (0.21 log units) above the measured one; low and high end bracket the measured number.
By their numbers in this assay, from the lowest: compounds 2, 1 and 4 (each within the scatter of the next); then compound 3.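

A single methoxy on the benzyl ring is enough for a modest gain: this assay shows a 3.2-fold lower number from compound 3 to compound 4 (0.51 log units; beyond the scatter) for 3-methoxybenzyl over benzyl. The second methoxy of compound 1 adds nothing that can be read, with a 1.2-fold higher number from compound 1 to compound 4 (0.08 log units; within the scatter) as the step, and 3-methoxyphenyl also matches the 2,3-dihydro-1,4-benzodioxin-2-yl group, with a 1.3-fold higher number from compound 2 to compound 4 (0.12 log units; within the scatter) as the step. No measurement at hand explains these steps.

As far as these compounds go, whether hydroxy, fluoro or an amine on this aromatic carbon would give a similar step remains open. So does the effect of a larger alkoxy group, such as ethoxy.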